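From hydroxycarbamoyl to ((hydroxycarbamoyl)oxy)methyl: a single anchor value

The source may report more compounds than this note shows. Statements on the series, on what has been measured and on what is new or still open speak of the compounds shown alone.

Within the data shown here, in a functional assay on cells (Homo sapiens) for inhibition, read by MTT assay, with a stated time of 48 h (a higher number here means a weaker inhibitor, a lower number a stronger inhibitor), compound 3 `O=C(COCCOc1no[n+]([O-])c1S(=O)(=O)c1ccccc1)NO` gives 19800 nM, the only number available. Compound 1 `O=S(=O)(c1ccccc1)c1c(OCCCCCCO)no[n+]1[O-]` is recorded as "not determined" (no result reported). Compound 2 `O=C(CCCCCCCOc1no[n+]([O-])c1S(=O)(=O)c1ccccc1)NO` is recorded as "not determined" (no result reported). Among the measured compounds shown here, compound 3 therefore cannot yet be ranked against another compound, and no measured step exists to calibrate the next change.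

Compound 4 `O=C(NO)OCCOCCOc1no[n+]([O-])c1S(=O)(=O)c1ccccc1` differs from compound 3 as follows: ((hydroxycarbamoyl)oxy)methyl in place of hydroxycarbamoyl on a saturated chain carbon bound to an oxygen on a saturated carbon. In words, ((hydroxycarbamoyl)oxy)methyl stands in place of hydroxycarbamoyl on a saturated chain carbon bound to an oxygen on a saturated carbon. The shared core stays unchanged.

For the measured compounds named here, with no precedent for this change, the working expectation stays anchored on compound 3 at 19800 nM, and the range is kept wide. The expected step is a 1.3-fold lower number from compound 3 to compound 4 (0.12 log units; within the scatter), slightly toward a stronger inhibitor in this assay and not beyond the scatter. For compound 4 the estimated value is 15000 nM, with an expected range of 5000 nM to 45000 nM.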

Compound 4, half-maximal inhibitory concentration: 19400 nM
Estimate against measurement, compound 4: 1.3-fold (0.11 log units) below; low and high end bracket the measured number.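

In this assay, ((hydroxycarbamoyl)oxy)methyl in place of hydroxycarbamoyl on a saturated chain carbon bound to an oxygen on a saturated carbon gives a 1.0-fold lower number from compound 3 to compound 4 (0.01 log units; within the scatter). Among these compounds, the series thus gains its only measured step, and at this place the read-out does not separate the two groups, a finding that holds for this single pair alone. No supporting data bear on why the two groups read alike.

On these data alone, whether a carboxylic acid or an amine at the same place would read apart from hydroxycarbamoyl remains open. Also open, as far as these compounds go, is whether a longer chain carrying ((hydroxycarbamoyl)oxy)methyl would read level with these two compounds, or whether this single step holds on any other variant of the shared core.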